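This account rests on a few compounds, and the source may have more. Where it says the series, first, only, none or still open, it means among the compounds named here.

Measured so far in an in vitro ADME assay on microsomes from liver (Mus musculus) for pharmacokinetics, read by LC-MS, with a stated time of 10 min, tested at 1 uM; on this read-out lower numbers stand for slow clearance and higher numbers for fast clearance:
- compound 1, `CN1C[C@H](C(=O)Nc2ccc(C#N)cc2)[C@@H](c2ccc(/C=C/C(=O)Nc3ccccc3N)cc2)C1`, gives 35 mL/min/kg
- compound 2, `CC(C)c1ccc(NC(=O)[C@H]2CN(C)C[C@@H]2c2ccc(/C=C/C(=O)Nc3ccccc3N)cc2)cc1`, gives 54 mL/min/kg
- compound 3, `CN1C[C@H](C(=O)Nc2ccc(F)c(F)c2)[C@@H](c2ccc(/C=C/C(=O)Nc3ccccc3N)cc2)C1`, gives 46 mL/min/kg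

All three share a core and differ only in the group on the amide-type nitrogen. Compound 3 stands second highest of the three numbers in this assay; its nearest neighbour is compound 2 with a 1.2-fold lower number from compound 2 to compound 3 (0.07 log units; within the scatter), and its furthest is compound 1 with a 1.3-fold higher number from compound 1 to compound 3 (0.12 log units; within the scatter), so the three values are indistinguishable on this read-out. The remaining pair also sits together: a 1.5-fold higher number from compound 1 to compound 2 (0.19 log units; within the scatter).

Compound 4, `CN1C[C@H](C(=O)NC2CC2)[C@@H](c2ccc(/C=C/C(=O)Nc3ccccc3N)cc2)C1`, is the next step from compound 3. The change is cyclopropyl in place of 3,4-difluorophenyl on an amide-type nitrogen. Among the compounds with values here, the steps measured at this position so far exchange one aromatic ring for another, and each of them stayed within the scatter; no measured step replaces the aromatic ring by a three-membered non-aromatic ring, so there is no direct precedent in this assay. With every change at this nitrogen so far giving nothing beyond the scatter, compound 4 is expected to stay in the same band, with an estimated 1.2-fold lower number from compound 3 to compound 4 (0.06 log units; within the scatter). For compound 4 the estimate in this assay is 40 mL/min/kg, with a range from 20 mL/min/kg to 80 mL/min/kg.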

Compound 4, clearance: 7 mL/min/kg
The estimate for compound 4 lay 5.7-fold (0.76 log units) above the measured number, and the stated range ends above it.
By their numbers in this assay, from the lowest: compound 4; then compounds 1, 3 and 2 (each within the scatter of the next).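

In this assay the amide-type nitrogen turns out to be a position that can move the number: a 6.6-fold lower number from compound 3 to compound 4 (0.82 log units; beyond the scatter) and a 7.7-fold lower number from compound 2 to compound 4 (0.89 log units; beyond the scatter) and a 5.0-fold lower number from compound 1 to compound 4 (0.70 log units; beyond the scatter) all lie beyond the scatter, while compound 1, compound 2 and compound 3 remain within the scatter of one another. The outcome holds whichever of the three substituted phenyl groups cyclopropyl replaces, so the separation in this set lies between those aromatic groups and cyclopropyl, not among the aromatic groups. No measurement here accounts for the lower number.

The change swaps a six-membered aromatic ring for a smaller non-aromatic ring, and these compounds cannot separate ring type from size. Cyclohexyl, an open chain such as isopropyl or a longer chain on this nitrogen would test that.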